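The compounds below may be only part of what the source reports. "The series", "measured", "known", "first", "only" and "open" are said of these compounds alone.

Measured so far in a functional assay on MT2 cells (Homo sapiens) for cytotoxicity, read by MTT assay; a higher number here means that more compound is tolerated, a lower number that less compound is tolerated:
compound 1 `CC(C)=CCOc1cc(Nc2nccs2)ccc1C#N`: 750 nM
compound 2 `N#Cc1ccc(Nc2nccs2)cc1OCc1ccco1`: 18000 nM
compound 3 `Clc1ccc(Nc2nccs2)cc1OCc1cccs1`: 38000 nM

Compound 3 stands highest of the three, with compound 2 nearest and compound 1 furthest, both gaps beyond the scatter. Next is compound 4 `N#Cc1ccc(Nc2nccs2)cc1OCc1cccs1`, with cyano in place of chloro on an aromatic carbon. Going by the values given here, no measured step covers this swap. Among the compounds with values here, the only measured step, a 24-fold higher number from compound 1 to compound 2 (1.38 log units; beyond the scatter), is large but concerns a different place, furan-2-yl in place of 2-methylprop-1-en-1-yl. Compound 4 will carry cyano as compound 2 does, and compound 2 gives 18000 nM, so no step beyond the scatter is expected in this assay, if anything toward a lower number. The estimated step is a 1.7-fold lower number from compound 3 to compound 4 (0.24 log units; within the scatter). For compound 4 the expected value is 22000 nM, with an estimated range of 7000 nM to 60000 nM.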

Compound 4, half-maximal cytotoxic concentration: 4100 nM
Compound 4: the middle estimate sits 5.4-fold (0.73 log units) above what was measured, outside the stated range (below it).
By their numbers in this assay, from the lowest: compound 1; then compound 4; then compound 2; then compound 3.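

In this assay the aromatic carbon para to the (1,3-thiazol-2-yl)amino group proves responsive, with a 9.3-fold lower number from compound 3 to compound 4 (0.97 log units; beyond the scatter) when cyano replaces chloro. With cyano held, the group on the chain carbon also counts: a 4.4-fold lower number from compound 2 to compound 4 (0.64 log units; beyond the scatter) for thiophen-2-yl in place of furan-2-yl and a 5.5-fold higher number from compound 1 to compound 4 (0.74 log units; beyond the scatter) for thiophen-2-yl in place of 2-methylprop-1-en-1-yl. No measured evidence bears on these steps.

Going by these compounds, whether the cyano-for-chloro step holds with furan-2-yl or 2-methylprop-1-en-1-yl on the chain remains open. So does the outcome with an amine or a carboxylic acid on this aromatic carbon.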